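Swapping a bromophenyl for a pyridyl on a hydrazone

This account rests on a few compounds, and the source may have more. Where it says the series, first, only, none or still open, it means among the compounds named here.

Measured so far:
Compound 1 `N/C(CC(O)c1cccc2ccccc12)=N\N=C\c1ccc(C(F)(F)F)cc1`: 26000 nM
Compound 2 `N/C(CC(O)c1cccc2ccccc12)=N\N=C\c1cccc(Br)c1`: 3900 nM
Compound 3 `N/C(CC(O)c1ccc2ccccc2c1)=N\N=C\c1ccco1`: "not determined" (no result reported)

These compounds share a core carrying a hydroxyl, a naphthalene and a hydrazone, and differ in the aryl group hung on the carbon with a double bond to nitrogen. In an ADME assay on L6 cells (Rattus norvegicus) for cytotoxicity, read by resazurin assay, with a stated time of 72 h (a lower number here means a stronger inhibitor, a higher number a weaker inhibitor), compound 2 gives 3900 nM and compound 1 gives 26000 nM. Of the two numbers, compound 2 stands lowest, and its gap to compound 1 lies beyond the scatter. Compound 3 has no number in this assay.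

Compound 4 `N/C(CC(O)c1cccc2ccccc12)=N\N=C\c1cccnc1` is not yet measured. It differs from compound 2 in one place: pyridin-3-yl in place of 3-bromophenyl on a carbon with a double bond to nitrogen. For the measured compounds named here, no measured pair shows this change, so the size of the step is guesswork; a moderate rise toward a weaker number is expected, but the data cannot rule out no change beyond the scatter. Compound 4 is expected to give about 12000 nM, somewhere between 4000 nM and 40000 nM. That expectation corresponds to a step of a 3.1-fold higher number from compound 2 to compound 4 (0.49 log units; beyond the scatter).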

Compound 4, half-maximal inhibitory concentration: 22000 nM
Beside the measured number, compound 4's estimate is 1.8-fold (0.26 log units) below it, within the range that was stated.
By their numbers in this assay, from the lowest: compound 2; then compounds 4 and 1 (each within the scatter of the next).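

In this assay, for the compounds shown here, putting pyridin-3-yl in place of 3-bromophenyl gives a 5.6-fold higher number from compound 2 to compound 4 (0.75 log units; beyond the scatter) and is the first single change that can be read at this position. It shows that the aryl group on this carbon can move the number beyond the usual scatter, even though a six-membered aromatic ring stays in place. The swap removes a bromine and adds a ring nitrogen that counts as a hydrogen-bond acceptor, but no measurement here explains the rise or shows which of these two differences matters.

As far as these compounds go, what remains open is how the bromine and the ring nitrogen each contribute. A plain phenyl on this carbon would help separate the two, while a ring carrying an amine or a carboxylic acid would show how the number responds to quite different groups.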